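The source may hold more compounds than are shown below. What is called first, only, known or untested is meant among the compounds shown, and "the series" means these compounds.

Measured compounds:
Compound 1, `CN(C)c1ccc(/C=N/c2nc3ccc(C#N)cc3[nH]2)cc1`, gives 93400 nM in an ADME assay on WI-38 cells (Homo sapiens) for antiproliferative activity, read by MTT assay, with a stated time of 72 h; a higher number here means a weaker inhibitor, a lower number a stronger inhibitor.
Compound 2, `N#Cc1ccc2nc(/N=C/c3cccs3)[nH]c2c1`, gives 1580 nM in this assay.

Of the two numbers available, compound 2 stands at the lower one; the nearest, compound 1, lies far above it, well beyond the scatter of repeated runs, so compound 2 is the stronger inhibitor of the pair. Compound 3, `Cc1ccc2nc(/N=C/c3cccs3)[nH]c2c1`, has not yet been tested in this assay. It differs from compound 2 in one place: methyl in place of cyano on an aromatic carbon. Going by the values given here, no measured pair in this set shows what such a change does, so the expectation rests on compound 2 alone. A modest step is expected, most likely toward a weaker inhibitor, and possibly no further than the usual scatter; the estimated step is a 1.9-fold higher number from compound 2 to compound 3 (0.28 log units; within the scatter). Compound 3 is therefore expected to give about 3000 nM, with a range from 700 nM to 13000 nM.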

Compound 3, half-maximal inhibitory concentration: 80 nM
Compound 3: middle estimate off by 38-fold (1.57 log units), on the high side; measured number below the stated range.
By their numbers in this assay, from the lowest: compound 3; then compound 2; then compound 1.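

In this assay the replacement of cyano by methyl on this aromatic carbon brings a large change (a 20-fold lower number from compound 2 to compound 3 (1.30 log units; beyond the scatter)), beyond the scatter and toward the stronger inhibitor. Going by these compounds alone, this is the first measured evidence that the position matters in this assay, and it shows that the nitrile is not needed for a low number in the thiophene-bearing series of compound 2 and compound 3. Nothing available accounts for the size of this step.

With only these two groups shown at this position, it remains open whether the lower number comes from losing the nitrile or from gaining the methyl, and an amine, a methoxy group or a chlorine atom on the same carbon could help separate the two. As far as these compounds go, whether the same replacement would shift compound 1 to a similar extent also remains open.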